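The source may hold more compounds than are shown below. What is called first, only, known or untested is meant among the compounds shown, and "the series" means these compounds.

The series shares the core of compound 1 `CC[C@H](C)[C@H](N)CN(C(=O)[C@@H]1C[C@H]1c1ccccc1)c1ccc(-c2ccccc2)cc1`, varied at the aromatic ring carried on the three-membered ring. In a functional assay for agonist activity at G protein-coupled receptor 88 (Homo sapiens), read by HTRF and cAMP accumulation (on this read-out higher numbers stand for an effect only at larger amounts of compound and lower numbers for an effect already at smaller amounts), compound 1 gives 230 nM; 800 nM (2 entries); the spread between these repeats, (the several entries of compound 1 in this assay, 230 nM; 800 nM (2 entries)), shows how much a single number can carry here. Compound 2 `CC[C@H](C)[C@H](N)CN(C(=O)[C@@H]1C[C@H]1c1cccc(Cl)c1)c1ccc(-c2ccccc2)cc1` gives 2200 nM in this assay. Compound 3 `CC[C@H](C)[C@H](N)CN(C(=O)[C@@H]1C[C@H]1c1ccc(F)cc1F)c1ccc(-c2ccccc2)cc1` gives 1300 nM in this assay, the lowest of the two single numbers, with compound 2 nearest; the step of a 1.7-fold lower number from compound 2 to compound 3 (0.23 log units; within the scatter) stays within the scatter, so these two are not ordered by the data. Compound 1, with no single number, is not placed against them.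

Compound 4 `CC[C@H](C)[C@H](N)CN(C(=O)[C@@H]1C[C@H]1c1cncnc1)c1ccc(-c2ccccc2)cc1` carries pyrimidin-5-yl in place of 2,4-difluorophenyl on a saturated ring carbon. Among the measured compounds shown here, the only measured step, a 1.7-fold lower number from compound 2 to compound 3 (0.23 log units; within the scatter), exchanged one substituted phenyl for another and stayed within the scatter; no measured step puts a pyrimidin-5-yl ring in this place, and the repeats of compound 1, (the several entries of compound 1 in this assay, 230 nM; 800 nM (2 entries)), show that differences of that size arise from scatter alone. For compound 4, therefore, no step beyond the scatter is expected in this assay, with the range held wide toward higher numbers since the measured steps do not cover this ring. Compound 4 is expected at 2500 nM, between 700 nM and 9000 nM. The expected step is a 1.9-fold higher number from compound 3 to compound 4 (0.28 log units; within the scatter).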

Compound 4, half-maximal effective concentration: 19000 nM
The estimate for compound 4 lay 7.6-fold (0.88 log units) below the measured number; measured number outside the range, above it.
By their numbers in this assay, from the lowest: compounds 3 and 2 (each within the scatter of the next); then compound 4.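

In this assay, this place on the three-membered ring does not treat all aromatic rings alike: the two substituted phenyl rings of compound 2 and compound 3 stay within the scatter of each other, while pyrimidin-5-yl moves the number well beyond it (a 15-fold higher number from compound 3 to compound 4 (1.16 log units; beyond the scatter); an 8.6-fold higher number from compound 2 to compound 4 (0.94 log units; beyond the scatter)). The change removes a six-membered aromatic ring of carbon only and brings in one with 2 hetero atoms and 2 hydrogen-bond acceptors, so the position separates these ring types, although a single example cannot show which feature of the new ring matters. Both steps are also wider than the spread between the repeats of the parent, so that spread does not account for the separation: (the several entries of compound 1 in this assay, 230 nM; 800 nM (2 entries)).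

Still open, on these data alone, is whether one ring nitrogen, as in pyridin-3-yl, already gives a shift of this size or whether both ring nitrogens of pyrimidin-5-yl are needed. Also open, as far as these compounds go, is whether a phenyl ring carrying a methoxy group or a nitrile stays with the substituted phenyl rings or moves toward compound 4.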